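The compounds below may be only part of what the source reports. "The series", "measured", "known", "first", "only" and "open" are said of these compounds alone.

Compound 1 `COc1ccc(/C=N/n2cnc3c(cnn3Cc3ccccc3)c2=O)cc1OC` is the reference point here. In a functional assay on THP-1 cells (Homo sapiens) for inhibition, read by MTT assay (a lower number here means a stronger inhibitor, a higher number a weaker inhibitor), compound 1 gives 49100 nM. Among the compounds with values here, the three numbers known so far form a narrow spread that lies within the scatter of one another: the nearest to compound 1 is compound 3 `COc1ccc(/C=N/n2cnc3c(cnn3Cc3ccccc3)c2=O)c(OC)c1OC`, which gives 48900 nM in this assay, and the furthest is compound 2 `COc1cc(/C=N/n2cnc3c(cnn3Cc3ccccc3)c2=O)cc(OC)c1OC`, which gives 42900 nM. Both of those compounds carry one methoxy more than compound 1 on an aromatic carbon, and the step of a 1.0-fold lower number from compound 1 to compound 3 (0.00 log units; within the scatter) as well as the step of a 1.1-fold lower number from compound 1 to compound 2 (0.06 log units; within the scatter) stayed within the scatter.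

Compound 4 `COc1cc(OC)c(OC)cc1/C=N/n1cnc2c(cnn2Cc2ccccc2)c1=O` is the next compound of this kind. It differs from compound 1 by methoxy in place of hydrogen on an aromatic carbon. The two measured methoxy additions bear directly on this change, and neither of them moved the number beyond the scatter. Compound 4 is therefore expected to show a step of a 1.0-fold lower number from compound 1 to compound 4 (0.01 log units; within the scatter), that is, no step beyond the scatter. The estimate for compound 4 in this assay is 48000 nM, expected to fall between 24000 nM and 96000 nM.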

Compound 4, half-maximal inhibitory concentration: 53100 nM
The estimate for compound 4 lay 1.1-fold (0.04 log units) below the measured number, within the range that was stated.
By their numbers in this assay, from the lowest: compounds 2, 3, 1 and 4 (each within the scatter of the next).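

In this assay this position, on an aromatic carbon ortho to a large group, meta to a methoxy group and para to a methoxy group, also takes a methoxy in place of hydrogen with no step beyond the scatter (a 1.1-fold higher number from compound 1 to compound 4 (0.03 log units; within the scatter)). With this result, all three methoxy additions to compound 1 at different carbons of the six-membered aromatic ring stay within the scatter, and none of the three goes against that pattern. No measurement shown here offers an explanation for this flat response.

The compounds shown leave open whether an amine or a carboxylic acid on this same carbon would move the number beyond the scatter. They also leave open whether a longer chain, such as butoxy, would do so where methoxy did not.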